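Iodo for fluoro on the core of compound 1

This account rests on a few compounds, and the source may have more. Where it says the series, first, only, none or still open, it means among the compounds named here.

Two numbers exist so far in a functional assay on COLO 205 cells (Homo sapiens) for inhibition, read by sulforhodamine B assay, with a stated time of 48 h, tested at 50 uM; a higher number here means more inhibition of growth at the concentration tested, a lower number less inhibition of growth. Compound 1 `O=C1C(=O)N(CCCCn2cc(COc3cc(=O)oc4ccccc34)nn2)c2ccc(F)cc21` gives 64%, which places it at the top of the two, though compound 2 `O=C1C(=O)N(CCCCCn2cc(COc3cc(=O)oc4ccccc34)nn2)c2ccccc21` gives 62% and the gap between the two lies within the scatter, so the pair cannot be told apart. Among the measured compounds shown here, compound 1 and compound 2 differ in more than one place, so no single step connects them.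

Compound 3 `O=C1C(=O)N(CCCCn2cc(COc3cc(=O)oc4ccccc34)nn2)c2ccc(I)cc21` keeps the whole of compound 1 except for one exchange: iodo in place of fluoro on an aromatic carbon. For the measured compounds named here, no measured pair shows what an exchange of one group for another at this position does, so the size of the step is open. With nothing in the data pointing either way, the step of a number 4 percentage points lower from compound 1 to compound 3 (within the scatter) is expected to stay within the scatter, in no fixed direction. Compound 3 is accordingly estimated at 60%, with a range from 45% to 75% in this assay.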

Compound 3, percent growth inhibition at one concentration: 50%
For compound 3 the middle estimate is 10 percentage points above the measured one; the range from low to high includes it.
By their numbers in this assay, from the lowest: compound 3; then compounds 2 and 1 (each within the scatter of the next).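

In this assay, among the compounds shown here, the only single-place pair gives a number 14 percentage points lower from compound 1 to compound 3 (beyond the scatter) for iodo in place of fluoro on an aromatic carbon. This position, meta to a fused ring and para to a fused ring, therefore responds to the choice of halogen, at least on the core of compound 1. Nothing available speaks to what lies behind the step.

On these data alone, one pair cannot show whether growth inhibition tracks the halogen in any order, so chloro and bromo at this carbon remain open, as does hydrogen on the same chain. Also open, as far as these compounds go, are groups of another kind here, such as an amine or a carboxylic acid, and whether the step carries over to a longer chain.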